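The source may hold more compounds than are shown below. What is called first, only, known or untested is meant among the compounds shown, and "the series" means these compounds.

Measured so far:
compound 1 `COc1ccc(C(=O)/C=C/c2cc(OC)c(OC)c(OC)c2)c2c1C=CC(C)(C)O2`: > 10000 nM
compound 2 `COc1ccc(C(=O)/C=C/c2ccc(C(F)(F)F)cc2)c2c1C=CC(C)(C)O2`: > 10000 nM
compound 3 `COc1ccc(C(=O)/C=C/c2cccc3ccccc23)c2c1C=CC(C)(C)O2`: > 10000 nM

All three were tested in a functional assay on K562 cells (Homo sapiens) for antiproliferative activity, read by MTT assay, with a stated time of 24 h; on this read-out lower numbers stand for stronger inhibition and higher numbers for weaker inhibition. For compound 1 the result is only a limit of the assay, > 10000 nM. Compound 2 likewise gives only a limit, > 10000 nM. Compound 3 too reaches only a limit, > 10000 nM. Among the compounds with values here, compound 2 therefore stands where every measured compound stands, at the edge of what the assay can resolve, as the limit of > 10000 nM in this assay, at which 3 of the 3 values shown sit, shows; no measured compound separates itself from the others.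

Within the data shown here, the untested compound 4 `COc1ccc(C(=O)/C=C/c2ccc(O)cc2)c2c1C=CC(C)(C)O2` keeps the shared core of compound 2; the single change is hydroxy in place of trifluoromethyl on an aromatic carbon. Among the measured compounds shown here, no step between two measured compounds carries a number, so nothing here scales a change of this kind. With every measured value sitting at the same limit, the expectation for compound 4 is at most a small gain, and quite possibly another limit. Compound 4 is expected to give about 8000 nM, in the range 2000 nM to 30000 nM. The step this estimate means, an at least 1.2-fold lower number from compound 2 to compound 4 (0.09 log units; that floor lies within the scatter), is expected to stay within the scatter.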

Compound 4, half-maximal inhibitory concentration: > 10000 nM
Compound 4 gave a limit, no number (the forecaster's own chance of this, stated with the estimate: 60%); at least 1.2-fold (0.09 log units) between middle value and limit.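

In this assay, within the data shown here, compound 2 and compound 4 both give only a limit, so no step from one to the other can be read: the limit of > 10000 nM in this assay, at which 4 of the 4 values shown sit. The compounds shown leave open whether hydroxy and trifluoromethyl differ at all, and what change to the shared core would give a measurable number.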